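A few compounds are considered here, and "the series" means these few. Any claim that something is new, unique, unknown or untested is made for them only; others in the source may bear on it.

In a functional assay on the whole organism for inhibition, with Rattus norvegicus as the target (on this read-out higher numbers stand for an effect only at larger amounts of compound and lower numbers for an effect already at smaller amounts), compound 1 `COc1cccc(N2CCN(CCCCN3C(=O)SC4(CCCC4)C3=O)CC2)n1` gives > 100 mg/kg. That value is a limit of the assay, not a number. Within the data shown here, compound 2 `N#Cc1cccnc1N1CCN(CCCCN2C(=O)SC3(CCCC3)C2=O)CC1` gives 29.3 mg/kg, the only true number so far, so it is the sole firm reference point.

The next compound changes one group. Compound 3 `O=C1SC2(CCCC2)C(=O)N1CCCCN1CCN(c2ncccc2Cl)CC1` carries chloro in place of cyano on an aromatic carbon, turning 3-cyanopyridin-2-yl into 3-chloropyridin-2-yl (chloro in place of cyano on an aromatic carbon).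

Among the measured compounds shown here, only one measured step bears on this change: an at least 3.4-fold lower number from compound 1 to compound 2 (0.53 log units; beyond the scatter). From the compounds shown here alone, it is beyond the scatter, but it starts from the limit of > 100 mg/kg in this assay, at which 1 of the 2 values shown sits, so its true size is unknown. It also swapped 6-methoxypyridin-2-yl for 3-cyanopyridin-2-yl, a different change from the one at hand. It shows that the group on this ring can matter in this assay, but it does not give a direction for replacing cyano with chloro.

No step beyond the scatter is therefore expected, although a wide range is needed with so little data. The expected change is a 1.1-fold higher number from compound 2 to compound 3 (0.04 log units; within the scatter). Compound 3 is estimated at 32 mg/kg, with an expected range from 11 mg/kg to 95 mg/kg.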

Compound 3, dose for half-maximal effect: 50 mg/kg
Beside the measured number, compound 3's estimate is 1.6-fold (0.19 log units) below it, within the range that was stated.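

The swap of cyano for chloro gives a 1.7-fold higher number from compound 2 to compound 3 (0.23 log units; within the scatter) in this assay, so the two groups cannot be told apart at this position on the ring. Chloro counts no hydrogen-bond acceptor where cyano counts one, yet this pair shows no step beyond the scatter, so an acceptor in this place is not needed to keep a measurable effect at the doses shown. Replacing 6-methoxypyridin-2-yl with 3-chloropyridin-2-yl gives an at least 2.0-fold lower number from compound 1 to compound 3 (0.30 log units; that floor lies within the scatter), but this shows only a floor within the scatter, and its true size stays unknown because it starts from a limit of the assay rather than a number: the limit of > 100 mg/kg in this assay, at which 1 of the 3 values shown sits.

Among these compounds, what an amine, a carboxylic acid or a methyl group would do at this same ring position remains open, since cyano and chloro are the only two groups here with true numbers on both sides of a step. From the compounds shown here alone, it also remains open whether these two groups would stay as close together with a longer chain linking the shared core to the ring.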